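Moving a Hydroxyl Group on a Three-Armed Pyridine Core

The source may hold more compounds than are shown below. What is called first, only, known or untested is meant among the compounds shown, and "the series" means these compounds.

Measured compounds:
compound 1 `Oc1ccc(-c2cc(-c3ccccc3O)cc(-c3cccc(O)c3)n2)cc1`, 5370 nM
compound 2 `Oc1ccc(-c2cc(-c3cccc(O)c3)cc(-c3cccc(O)c3)n2)cc1`, 1940 nM

In a functional assay on DU-145 cells (Homo sapiens) for cytotoxicity, read by CCK-8 assay, with a stated time of 4 days (on this read-out lower numbers stand for stronger inhibition and higher numbers for weaker inhibition), compound 2 gives 1940 nM, the lowest number of the two measured, and compound 1 gives 5370 nM. Going by the values given here, the one known step, a 2.8-fold lower number from compound 1 to compound 2 (0.44 log units; beyond the scatter), shows that moving the hydroxyl group on one arm can matter.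

Compound 3 `Oc1ccc(-c2cc(-c3ccc(O)cc3)nc(-c3cccc(O)c3)c2)cc1` differs from compound 2 by 4-hydroxyphenyl in place of 3-hydroxyphenyl on an aromatic carbon. Among the compounds with values here, no measured pair shows this particular move, so the direction is open; a small change is expected, a 1.3-fold lower number from compound 2 to compound 3 (0.11 log units; within the scatter). Compound 3 is therefore estimated at 1500 nM, within 500 nM to 5000 nM.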

Compound 3, half-maximal inhibitory concentration: 5800 nM
Compound 3: the middle estimate sits 3.9-fold (0.59 log units) below what was measured; measured number above the stated range.
By their numbers in this assay, from the lowest: compound 2; then compounds 1 and 3 (each within the scatter of the next).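

On the arm opposite the ring nitrogen, 4-hydroxyphenyl brings a 3.0-fold higher number from compound 2 to compound 3 (0.48 log units; beyond the scatter) and so loses the gain seen with 3-hydroxyphenyl. Replacing 2-hydroxyphenyl with 4-hydroxyphenyl at this position gives a 1.1-fold higher number from compound 1 to compound 3 (0.03 log units; within the scatter) and so does not separate those two arms. Of these three hydroxyl placements, only 3-hydroxyphenyl stands apart, with the lowest number. Nothing available explains this preference. Still open, going by these compounds, is whether an amine or a carboxylic acid in place of this hydroxyl would lower the number further, and whether the other two arms respond in the same way.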